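Compound 4: amino-methoxyphenyl exchange on the acetyl series

The source may report more compounds than this note shows. Statements on the series, on what has been measured and on what is new or still open speak of the compounds shown alone.

Values in a functional assay on HL-60 cells (Homo sapiens) for cytotoxicity, read by MTT assay, with a stated time of 48 h (a higher number here means a weaker inhibitor, a lower number a stronger inhibitor), so far
- Compound 1 `COc1cc(-n2c(-c3ccc(O)cc3)c[nH]c2=O)cc(OC)c1OC` (20000 nM)
- Compound 2 `COc1ccc(-c2cn(C(=O)Nc3cc(OC)c(OC)c(OC)c3)c(=O)n2-c2cc(OC)c(OC)c(OC)c2)cc1O` (15400 nM)
- Compound 3 `COc1cc(-n2c(-c3ccc(Br)cc3)cn(C(C)=O)c2=O)cc(OC)c1OC` (200 nM)

Compound 3 has the lowest number of the three, and the gaps to compound 2 and compound 1 both lie well beyond the scatter. It is therefore the strongest inhibitor measured so far.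

Compound 4 `COc1ccc(-c2cn(C(C)=O)c(=O)n2-c2cc(OC)c(OC)c(OC)c2)cc1N` is still unmeasured. It retains the acetyl group and carries 3-amino-4-methoxyphenyl in place of 4-bromophenyl on an aromatic carbon. Among the compounds with values here, no two measured compounds differ in one place only, so the series offers no direct measure of a step of this kind. Among the measured compounds only compound 3 (200 nM) bears the acetyl group, which makes it the natural reference for compound 4. On this thin evidence, a moderate move toward a lower number in this assay is expected, though a result within the scatter of compound 3 would not be surprising. The estimated change is a 3.3-fold lower number from compound 3 to compound 4 (0.52 log units; beyond the scatter) and its uncertainty is wide. For compound 4 the expected value is 60 nM in an estimated range from 8 nM to 500 nM at this stage.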

Compound 4, half-maximal inhibitory concentration: 400 nM
Compound 4: the middle estimate sits 6.7-fold (0.82 log units) below what was measured; the measured number falls inside the stated range.
By their numbers in this assay, from the lowest: compounds 3 and 4 (each within the scatter of the next); then compounds 2 and 1 (each within the scatter of the next).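

With the acetyl group kept, 3-amino-4-methoxyphenyl in place of 4-bromophenyl on the aromatic carbon gives a 2.0-fold higher number from compound 3 to compound 4 (0.30 log units; within the scatter) in this assay. Within the data shown here, this is the first comparison that isolates a single place, and it shows that this position tolerates the exchange of a bromine-bearing aryl group for a larger one carrying amino and methoxy groups, with no change beyond the scatter. No measurement available here bears on the reason for this result.

The compounds shown leave open what each part of the new group contributes on its own, as a 3-aminophenyl or a 4-methoxyphenyl group at this position would separate the amino group from the methoxy group, while a 4-chlorophenyl or an unsubstituted phenyl group would test whether the bromine can be replaced or removed. They also leave open how far this tolerance extends, for instance to a carboxylic acid or a dimethylamino group in place of the amino group, and whether it holds with a propanoyl group in place of the acetyl group.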